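Hydroxamic Acid Series: Benzyl Substitution at the Piperidine Nitrogen

The source may report more compounds than this note shows. Statements on the series, on what has been measured and on what is new or still open speak of the compounds shown alone.

Compound 1 `CN(Cc1nc(C2CCN(Cc3ccccc3)CC2)no1)c1ncc(/C=C/C(=O)NO)cn1` — 547 nM
Compound 2 `CN(Cc1nc(C2CCN(Cc3ccccc3F)CC2)no1)c1ncc(C(=O)NO)cn1` — 98.6 nM

In a functional assay on Raji cells (Homo sapiens) for antiproliferative activity, read by MTT assay, with a stated time of 72 h (a higher number here means a weaker inhibitor, a lower number a stronger inhibitor), compound 2 gives 98.6 nM, the lowest of the two numbers recorded; compound 1 gives 547 nM, a gap beyond the scatter. Compound 3 `CN(Cc1nc(C2CCN(Cc3ccc(C#N)cc3)CC2)no1)c1ncc(C(=O)NO)cn1` keeps the core of compound 2 and differs only in the benzyl group: 4-cyanophenyl in place of 2-fluorophenyl on a saturated chain carbon bound to an amine nitrogen in a ring. For the measured compounds named here, with no measured pair differing in this way alone, any expectation rests on compound 2 alone. The step is expected to be small, a 1.3-fold higher number from compound 2 to compound 3 (0.12 log units; within the scatter), not clearly beyond the scatter in either direction. Compound 3 is therefore expected to give 130 nM, within 50 nM to 340 nM.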

Compound 3, half-maximal inhibitory concentration: 117 nM
Beside the measured number, compound 3's estimate is 1.1-fold (0.05 log units) above it; the range from low to high includes it.
By their numbers in this assay, from the lowest: compounds 2 and 3 (each within the scatter of the next); then compound 1.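

In this assay, for the compounds shown here, the change from 2-fluorobenzyl to 4-cyanobenzyl gives a 1.2-fold higher number from compound 2 to compound 3 (0.07 log units; within the scatter) and is the first step read at this place, on a saturated chain carbon bound to an amine nitrogen in a ring. The two groups, which differ in substituent and in its ring location, cannot be told apart in this read-out. Nothing available bears on why the numbers stay so close. Still open, on these data alone, is whether a carboxylic acid or an amine in place of the nitrile, or a phenethyl group in place of the benzyl group, would hold up equally well. The separate contributions of the nitrile and of its ring location also remain unresolved.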